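The source may hold more compounds than are shown below. What is called first, only, known or untested is meant among the compounds shown, and "the series" means these compounds.

Compound 1 `FC(F)(F)Oc1ccccc1Oc1ccnc(N2CCC(NC(=S)Nc3cccnc3)CC2)c1Cl`: 96 nM
Compound 2 `Cc1c(Oc2ccc(OC(F)(F)F)cc2)ccnc1N1CCC(NC(=S)Nc2cccnc2)CC1`: 26 nM
Compound 3 `S=C(Nc1cccnc1)NC1CCN(c2ncccc2Cl)CC1`: a limit of the assay, > 5000 nM

In an assay on membranes from brain for binding affinity to Lysophosphatidylserine lipase ABHD12 (Mus musculus), read by fluorescence, with a stated time of 20 min (a lower number here means a stronger inhibitor, a higher number a weaker inhibitor), compound 1 gives 96 nM, the higher of the two numbers reported in this assay; compound 2 sits at 26 nM, a gap beyond the usual scatter. For compound 3 the result is only a limit, > 5000 nM, with no number behind it.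

Compound 4 `FC(F)(F)Oc1ccc(Oc2ccnc(N3CCC(NC(=S)Nc4cccnc4)CC3)c2Cl)cc1Cl` is not yet measured. It differs from compound 1 in 3-chloro-4-(trifluoromethoxy)phenyl in place of 2-(trifluoromethoxy)phenyl on an oxygen on an aromatic ring. Among the compounds with values here, compounds 1 and 2 differ in more than one place, so no single measured step covers this change. The step is expected to be a 1.9-fold lower number from compound 1 to compound 4 (0.28 log units; within the scatter), towards a lower number or none beyond the scatter. Compound 4 is expected at 50 nM, in the range 15 nM to 160 nM.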

Compound 4, half-maximal inhibitory concentration: 33 nM
For compound 4 the middle estimate is 1.5-fold (0.18 log units) above the measured one, within the range that was stated.
By their numbers in this assay, from the lowest: compounds 2 and 4 (each within the scatter of the next); then compound 1. At a limit, above all of these: compound 3.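

In this assay, 3-chloro-4-(trifluoromethoxy)phenyl in place of 2-(trifluoromethoxy)phenyl on the oxygen gives a 2.9-fold lower number from compound 1 to compound 4 (0.46 log units; beyond the scatter). Within the data shown here, this is the first single-place step, and it shows that the aryl group on this oxygen can move the number beyond the scatter. The compounds shown give no measured cause for the step.

The two aryl groups differ both by the added chlorine and by where the trifluoromethoxy group sits, and the compounds shown do not separate these two changes. From the compounds shown here alone, how an amine or a carboxylic acid on this aryl ring would read also remains open.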